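The source may report more compounds than this note shows. Statements on the series, on what has been measured and on what is new or still open speak of the compounds shown alone.

Measured so far in a functional assay on HeLa cells (Homo sapiens) for antiproliferative activity, read by cell counting, with a stated time of 3 days; on this read-out higher numbers stand for weaker inhibition and lower numbers for stronger inhibition:
compound 1 `CC(Nc1ccccc1Oc1cccc(N)c1)=C1C(=O)CC(c2ccccc2)CC1=O` — 82 nM
compound 2 `CC(Nc1ccccc1Oc1ccc(C(C)O)cc1)=C1C(=O)CC(c2ccccc2)CC1=O` — 75 nM

Compound 2 gives the lowest of the two numbers in this assay, but the step of a 1.1-fold lower number from compound 1 to compound 2 (0.04 log units; within the scatter) is within the scatter, so the two stand level. Compound 3 `CCOc1ccccc1NC(C)=C1C(=O)CC(c2ccccc2)CC1=O` differs from compound 2 as follows: ethyl in place of 4-(1-hydroxyethyl)phenyl on an oxygen on an aromatic ring. For the measured compounds named here, the single measured step swaps one aryl group on that oxygen for another and says nothing about replacing the aryl by ethyl, so no measured step bears directly on this change. The estimate for compound 3 therefore rests on compound 2 alone, with a wide range: 150 nM (40 nM to 800 nM), an expected step of a 2.0-fold higher number from compound 2 to compound 3 (0.30 log units; within the scatter).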

Compound 3, half-maximal inhibitory concentration: 180 nM
Compound 3: middle estimate off by 1.2-fold (0.08 log units), on the low side; the range from low to high includes it.
By their numbers in this assay, from the lowest: compounds 2 and 1 (each within the scatter of the next); then compound 3.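

In this assay ethyl in place of 4-(1-hydroxyethyl)phenyl gives a 2.4-fold higher number from compound 2 to compound 3 (0.38 log units; beyond the scatter) and ethyl in place of 3-aminophenyl gives a 2.2-fold higher number from compound 1 to compound 3 (0.34 log units; beyond the scatter) at the same oxygen on an aromatic ring. Both steps are modest, but unlike the exchange of one aryl group for the other, they lie beyond the scatter, so this position does respond to the change from aryl to ethyl. No evidence at hand explains this difference. Open, from the compounds shown here alone, is where a longer chain such as butyl, or a chain ending in an amine, would stand relative to ethyl and the two aryl groups.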